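A few compounds are considered here, and "the series" means these few. Any claim that something is new, unique, unknown or untested is made for them only; others in the source may bear on it.

Measured so far in a functional assay on HT-29 cells (Homo sapiens) for cytotoxicity, read by MTT assay, with a stated time of 72 h; a higher number here means a weaker inhibitor of growth, a lower number a stronger inhibitor of growth:

Compound 1 `CS/C(=N\C(=O)c1csc([N+](=O)[O-])c1)NC(=O)c1csc([N+](=O)[O-])c1` gives > 100000 nM, which is a limit of the assay and not a number.

Compound 2 `CS/C(=N\C(=O)c1ccco1)NC(=O)c1ccco1` gives > 100000 nM, again a limit of the assay and not a number.

Compound 3 `O=C(/N=C(/NC(=O)c1ccco1)[Se]Cc1ccccc1)c1ccco1` gives 89100 nM.

Compound 3 is made from compound 2 by one change, (a group of 8 heavy atoms (7 carbon, 1 selenium; one six-membered aromatic ring of carbon only) in place of a group of 2 heavy atoms (1 carbon, 1 sulfur; no ring), on a carbon with a double bond to nitrogen). The step it made in this assay is an at least 1.1-fold lower number from compound 2 to compound 3 (0.05 log units; that floor lies within the scatter). In plain terms, the number for compound 3 sits close to the limit that compound 2 reached, and a gap of that size is too small to be read as a real difference; the evidence on the measured values is the limit of > 100000 nM in this assay, at which 2 of the 3 values shown sit.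

Compound 4 `O=C(/N=C(/NC(=O)c1csc([N+](=O)[O-])c1)[Se]Cc1ccccc1)c1csc([N+](=O)[O-])c1` is the compound that has not yet been measured. It stands to compound 1 exactly as compound 3 stands to compound 2: the change is a group of 8 heavy atoms (7 carbon, 1 selenium; one six-membered aromatic ring of carbon only) in place of a group of 2 heavy atoms (1 carbon, 1 sulfur; no ring), on a carbon with a double bond to nitrogen, and the place it occurs is described in the same words for both pairs, so this is the same change on a different core. How the core of compound 1 differs from the core of compound 2 is not broken down here.

Within the data shown here, with only one earlier instance of this change, and that instance within the scatter, the expectation for compound 4 is a step of about a number no higher from compound 1 to compound 4 (the limit leaves the size open), resting on the earlier step of an at least 1.1-fold lower number from compound 2 to compound 3 (0.05 log units; that floor lies within the scatter) and on the fact that compound 1 itself reached only a limit, > 100000 nM. The estimate for compound 4 in this assay is therefore 100000 nM, expected to fall between 50000 nM and 200000 nM, with a real chance that the assay again reports only a limit.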

Compound 4, concentration for total growth inhibition: > 100000 nM
Compound 4 ended at the assay's limit; the forecaster's own chance of this, stated with the estimate: 60%; the middle value sits exactly at the limit.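

In this assay compound 4 gives > 100000 nM, which is a limit of the assay and not a number. Compound 1 also reached only a limit, so no step can be read from compound 1 to compound 4. The compounds shown leave open how large an effect, if any, this change of group has on the core of compound 1, and the evidence remains: the limit of > 100000 nM in this assay, at which 3 of the 4 values shown sit.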